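Hydrazone series: fluorohydroxyphenyl variant of compound 3

A few compounds are considered here, and "the series" means these few. Any claim that something is new, unique, unknown or untested is made for them only; others in the source may bear on it.

Working notes on a small set of hydrazones built on one shared core. Compound 3 `Cc1c(C(=O)N/N=C\c2ccccc2)oc2cccc(O)c12` carries an unsubstituted phenyl on the carbon with a double bond to nitrogen; in a functional assay on PC-3 cells (Homo sapiens) for inhibition (a lower number here means a stronger inhibitor, a higher number a weaker inhibitor), compound 3 gives 29200 nM. Compound 1 `Cc1c(C(=O)N/N=C\c2ccc(O)cc2)oc2cccc(O)c12` carries 4-hydroxyphenyl at that carbon, and in this assay compound 1 gives 21700 nM. For compound 2 `Cc1c(C(=O)N/N=C\c2ccncc2)oc2cccc(O)c12`, with pyridin-4-yl there, the result in this assay is only a limit of the assay, >= 40000 nM; this is the limit of >= 40000 nM in this assay, at which 1 of the 3 values shown sits. Compound 3 stands at the highest of the two actual numbers, but the step of a 1.3-fold higher number from compound 1 to compound 3 (0.13 log units; within the scatter) is within the scatter, so compound 1 and compound 3 are not told apart by it. The step of an at least 1.8-fold higher number from compound 1 to compound 2 (0.26 log units; that floor lies within the scatter) is a floor within the scatter, and an at least 1.3-fold lower number from compound 2 to compound 3 (0.13 log units; that floor lies within the scatter) is a floor of the same kind.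

Compound 4 `Cc1c(C(=O)N/N=C\c2cccc(F)c2O)oc2cccc(O)c12` differs from compound 3 by one change: 3-fluoro-2-hydroxyphenyl in place of phenyl on a carbon with a double bond to nitrogen. The measured step that bears most directly on this is a 1.3-fold higher number from compound 1 to compound 3 (0.13 log units; within the scatter), which also concerns a hydroxy on the aromatic ring attached to that carbon; read in the adding direction it gave a lowering of the number that stays within the scatter. Nothing measured speaks to fluorine on that ring. The expectation is therefore a step of a 1.3-fold lower number from compound 3 to compound 4 (0.12 log units; within the scatter) that remains within the scatter, tending if anything toward a slightly lower number. Compound 4 is estimated at 22000 nM in this assay, within a range from 9000 nM to 50000 nM.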

Compound 4, half-maximal inhibitory concentration: 12700 nM
Beside the measured number, compound 4's estimate is 1.7-fold (0.24 log units) above it; low and high end bracket the measured number.
By their numbers in this assay, from the lowest: compounds 4, 1 and 3 (each within the scatter of the next, the first and the last beyond it). At a limit, above all of these: compound 2.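

In this assay, the position on the carbon with a double bond to nitrogen now gives a step from a measured phenyl compound that lies beyond the scatter: a 2.3-fold lower number from compound 3 to compound 4 (0.36 log units; beyond the scatter). Among the compounds shown here, this shows that a change of the ring at this position can move the number, whereas the earlier steps there, including the floors, all lay within the scatter. The step of an at least 3.1-fold lower number from compound 2 to compound 4 (0.49 log units; beyond the scatter) is likewise beyond the scatter, but it is only a floor, as compound 2 holds a limit of the assay: the limit of >= 40000 nM in this assay, at which 1 of the 4 values shown sits.

The 3-fluoro-2-hydroxyphenyl and 4-hydroxyphenyl groups are not told apart, however, with a 1.7-fold lower number from compound 1 to compound 4 (0.23 log units; within the scatter). On these data alone, compound 4 brings in hydroxy and fluoro in a single change, so the share of each in the step from phenyl stays open. Also open, as far as these compounds go, is how the number responds to an amine or a carboxylic acid on this ring, and whether any group at this position moves it further than the values seen here.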